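This account rests on a few compounds, and the source may have more. Where it says the series, first, only, none or still open, it means among the compounds named here.

Compound 1 `NS(=O)(=O)c1ccc(N2N=C(c3ccc(OCc4ccccc4)cc3)CC2c2ccccc2)cc1`: > 100000 nM
Compound 2 `NS(=O)(=O)c1ccc(N2N=C(c3ccc(Oc4ccccc4)cc3)CC2c2ccccc2)cc1`: 42000 nM
Compound 3 `NS(=O)(=O)c1ccc(N2N=C(c3ccc(Oc4ccccc4)cc3)CC2c2cccc(Cl)c2)cc1`: 8000 nM

In an ADME assay on MT4 cells (Homo sapiens) for cytotoxicity, read by MTT assay, with a stated time of 96 h (on this read-out lower numbers stand for higher toxicity in this test and higher numbers for lower toxicity in this test), compound 1 gives > 100000 nM, which is a limit of the assay and not a number. Compound 1 thus stands at the edge of the measured range (the limit of > 100000 nM in this assay, at which 1 of the 3 values shown sits), at the low-toxicity end of the three values shown. Compound 4 `NS(=O)(=O)c1ccc(N2N=C(c3ccc(OCc4ccccc4)cc3)CC2c2ccc(Cl)cc2)cc1` differs from compound 1 by chloro in place of hydrogen on an aromatic carbon. The measured step that bears on this change is a 5.3-fold lower number from compound 2 to compound 3 (0.72 log units; beyond the scatter), the same kind of exchange of chloro for hydrogen on an aromatic carbon. A step of similar size and direction is expected here, toward a lower number in this assay, though the limit for compound 1 leaves its exact size open. Compound 4 is expected at 30000 nM, between 10000 nM and 100000 nM, a step of an at least 3.3-fold lower number from compound 1 to compound 4 (0.52 log units; beyond the scatter).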

Compound 4, half-maximal cytotoxic concentration: 70000 nM
Estimate against measurement, compound 4: 2.3-fold (0.37 log units) below; measured number inside the range.
By their numbers in this assay, from the lowest: compound 3; then compounds 2 and 4 (each within the scatter of the next). At a limit, above all of these: compound 1.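

In this assay, chloro on the core of compound 1 gives an at least 1.4-fold lower number from compound 1 to compound 4 (0.15 log units; that floor lies within the scatter), so this floor alone does not establish a change beyond the scatter. The change can now be compared on two cores: the same change on two cores in this assay, a 5.3-fold lower number (0.72 log units; beyond the scatter) from compound 2 to compound 3 and an at least 1.4-fold lower number (0.15 log units; that floor lies within the scatter) from compound 1 to compound 4; the limit leaves it open whether they differ The number for compound 1 is a limit of the assay, not a measured value: the limit of > 100000 nM in this assay, at which 1 of the 4 values shown sits.

The compounds shown leave open the true size of the step on this core. They also leave open how a fluoro, a methoxy or an amine in place of chloro at this position would read.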